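A Carbamate Swap on a Shared Kinase Inhibitor Core

The compounds below may be only part of what the source reports. "The series", "measured", "known", "first", "only" and "open" are said of these compounds alone.

Compound 2 `C[C@@H]1CN(C(=O)c2nc(Nc3cc(C4CC4)[nH]n3)c3cc(Cl)ccc3n2)CCN1C(=O)OCC(Cl)(Cl)Cl` is the higher of the two measured compounds: in an assay for inhibition of serine/threonine-protein kinase PAK 4 (Homo sapiens), read by FRET and Z'-LYTE, with a stated time of 60 min, tested at 5 uM, in the presence of a further agent that is not named here (on this read-out higher numbers stand for a stronger effect at the one concentration tested and lower numbers for a weaker effect), compound 2 gives 63%, while compound 1 `C[C@@H]1CN(C(=O)c2nc(Nc3cc(C4CC4)[nH]n3)c3cc(Cl)ccc3n2)CCN1C(=O)OC(C)(C)C` gives 22.7%. Compound 3 `CC(C)OC(=O)N1CCN(C(=O)c2nc(Nc3cc(C4CC4)[nH]n3)c3cc(Cl)ccc3n2)C[C@H]1C` is not yet measured and differs from compound 2 in one place: isopropyl in place of 2,2,2-trichloroethyl on an oxygen next to a carbonyl group. Among the compounds with values here, the one step that bears on this is a number 40.3 percentage points higher from compound 1 to compound 2 (beyond the scatter), which brought in the group that now leaves. Isopropyl stands closer to tert-butyl than to 2,2,2-trichloroethyl, so a fall back toward the level of compound 1 is expected. Compound 3 is estimated at 30%, with a range from 10% to 55%. The expected step is a number 33 percentage points lower from compound 2 to compound 3 (beyond the scatter).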

Compound 3, a percentage reported as inhibition, at one concentration (the size of the read-out at that concentration, not a potency): 75.8%
The estimate for compound 3 lay 45.8 percentage points below the measured number, outside the stated range (above it).
By their numbers in this assay, from the lowest: compound 1; then compound 2; then compound 3.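

On this oxygen, a single methyl decides much of the outcome: replacing it with hydrogen gives a number 53.1 percentage points higher from compound 1 to compound 3 (beyond the scatter) in this assay and turns tert-butyl into isopropyl. Chlorine is not needed for the high level, since isopropyl in place of 2,2,2-trichloroethyl gives a number 12.8 percentage points higher from compound 2 to compound 3 (beyond the scatter) and the all-carbon group ranks highest of the three. No measurement here accounts for this order. From the compounds shown here alone, how ethyl, cyclobutyl or a longer chain on the same oxygen would rank remains open, as does whether an amine there would hold this level.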